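Aryl variation on the piperazine: compound 3 to compound 4

The compounds below may be only part of what the source reports. "The series", "measured", "known", "first", "only" and "open" are said of these compounds alone.

Measured so far:
compound 1 `O=C(CN1CCN(c2ccccc2F)CC1)Nc1nc2ccccc2[nH]1` – 11.6%
compound 2 `O=C(CN1CCN(c2ccccn2)CC1)Nc1nc2ccccc2[nH]1` – 30.8%
compound 3 `O=C(CN1CCN(c2ncccn2)CC1)Nc1nc2ccccc2[nH]1` – 8.77%

In a functional assay, read by spectrophotometry, with a stated time of 30 min, tested at 5 ug/mL (on this read-out higher numbers stand for a stronger effect at the one concentration tested and lower numbers for a weaker effect), compound 3 gives 8.77%, the low end of the three numbers. Its gap to compound 1 is small, a number 2.8 percentage points lower from compound 1 to compound 3 (within the scatter), so the two are not separable; its gap to compound 2 is clearer, a number 22 percentage points lower from compound 2 to compound 3 (beyond the scatter), and the step of a number 19.2 percentage points higher from compound 1 to compound 2 (beyond the scatter) points the same way, compound 2 being apart from the other two.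

Compound 4 is `COc1ccccc1N1CCN(CC(=O)Nc2nc3ccccc3[nH]2)CC1`. The change from compound 3 is 2-methoxyphenyl in place of pyrimidin-2-yl on an amine nitrogen in a ring. Among the compounds with values here, only one measured step bears directly on it: the move between compound 1 and compound 3, a number 2.8 percentage points lower from compound 1 to compound 3 (within the scatter), which exchanged a carbon-only aromatic ring with a single ring substituent for the pyrimidin-2-yl and stayed within the scatter. Compound 4 returns to a carbon-only ring bearing a single substituent, the 2-methoxyphenyl, so no step beyond the scatter is expected in this assay; the direction, if any, is expected to be slightly upward, toward the number of compound 1. Within the data shown here, no measured pair shows a methoxy against a fluorine, so that part of the change is uncovered.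

For compound 4 the estimate in this assay is 13%, range 4% to 27%, an expected step of a number 4.2 percentage points higher from compound 3 to compound 4 (within the scatter).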

Compound 4, a percentage reported as activity, at one concentration (the size of the read-out at that concentration, not a potency): 10.8%
Beside the measured number, compound 4's estimate is 2.2 percentage points above it; low and high end bracket the measured number.
By their numbers in this assay, from the lowest: compounds 3, 4 and 1 (each within the scatter of the next); then compound 2.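

In this assay, within the data shown here, methoxy in place of fluoro on an aromatic carbon gives the first direct comparison of two substituents on a carbon-only ring, and the change does not register: a number 0.8 percentage points lower from compound 1 to compound 4 (within the scatter). The exchange of pyrimidin-2-yl for 2-methoxyphenyl on the amine nitrogen in a ring also leaves the read-out unresolved, a number 2 percentage points higher from compound 3 to compound 4 (within the scatter), so a carbon-only ring and a ring with two hetero atoms cannot be separated here. Against the pyridin-2-yl group the picture differs, a number 20 percentage points lower from compound 2 to compound 4 (beyond the scatter), which leaves compound 2 alone apart from compounds 1, 3 and 4 at this position; no available evidence accounts for that separation.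

The compounds shown leave open whether the higher number belongs to pyridin-2-yl alone or would also appear with a benzyl or cyclohexyl group on this nitrogen, or with an amine or carboxylic acid on the aromatic ring. With a single tested concentration, the numbers also leave open how the four compounds would rank in potency.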